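Halogen exchange on two cores of calpain-1 inhibitors

The source may hold more compounds than are shown below. What is called first, only, known or untested is meant among the compounds shown, and "the series" means these compounds.

Measured so far in an assay on isolated protein for inhibition of Calpain-1 catalytic subunit (Sus scrofa); on this read-out higher numbers stand for weaker inhibition and lower numbers for stronger inhibition:
- compound 1 `O=C(O)/C(S)=C/c1ccccc1Cl` gives 20700 nM
- compound 2 `O=C(O)/C(S)=C/c1c[nH]c2ccc(Br)cc12` gives 20 nM
- compound 3 `O=C(O)/C(S)=C/c1ccccc1Br` gives 9100 nM

Compound 2 stands lowest of the three; the difference between its core and the core of compound 3 is not broken down here. Within the core of compound 3 one change is measured, (chloro in place of bromo on an aromatic carbon), and it gave a 2.3-fold higher number from compound 3 to compound 1 (0.36 log units; beyond the scatter).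

Compound 4 `O=C(O)/C(S)=C/c1c[nH]c2ccc(Cl)cc12` is not yet measured. Going by the values given here, it arises from compound 2 by chloro in place of bromo on an aromatic carbon, the same kind of change as the one from compound 3 to compound 1, but not the same: here the chloro enters on a six-membered aromatic ring of carbon only that is part of a fused system of two rings, meta and para to a fused ring, whereas in compound 1 it sits ortho to a group of 6 heavy atoms. Among the compounds with values here, the step is expected to be about a 2.3-fold higher number from compound 2 to compound 4 (0.35 log units; beyond the scatter), resting on the single comparable step, a 2.3-fold higher number from compound 3 to compound 1 (0.36 log units; beyond the scatter), and on the value of compound 2, 20 nM. In this assay compound 4 is thus estimated at 45 nM, with a range of 15 nM to 130 nM expected.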

Compound 4, half-maximal inhibitory concentration: 50 nM
Beside the measured number, compound 4's estimate is 1.1-fold (0.05 log units) below it; the measured number falls inside the stated range.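

In this assay, chloro in place of bromo on an aromatic carbon gives a 2.5-fold higher number from compound 2 to compound 4 (0.40 log units; beyond the scatter), and this step agrees with the one on the other core: the same change on two cores in this assay, a 2.3-fold higher number (0.36 log units; beyond the scatter) from compound 3 to compound 1 and a 2.5-fold higher number (0.40 log units; beyond the scatter) from compound 2 to compound 4, 1.1-fold (0.04 log units) apart, within the scatter of two such steps. In these two pairs the change therefore carries from one core to the other, with the bromo compound giving the lower number on both cores and the size of the step holding within the scatter. This rests on two pairs only, with the halogen in a different place on each core, so it does not show that the step would hold on a further core or at another position, and it gives no reason for the step.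

From the compounds shown here alone, it remains open whether fluoro, iodo, methyl or methoxy at the same place on the core of compound 2 would continue this trend. Also open, going by these compounds, is whether a methyl ester or an amide in place of the carboxylic acid would leave the halogen step unchanged.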